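This account rests on a few compounds, and the source may have more. Where it says the series, first, only, none or still open, it means among the compounds named here.

Compound 1 `NC(=O)c1c(NC(=O)c2ccc(C(F)(F)F)cc2)sc2c1CCN(Cc1ccc(Cl)cc1)C2`: > 50000 nM
Compound 2 `NC(=O)c1c(NC(=O)c2ccccc2F)sc2c1CCN(Cc1c(Cl)cccc1Cl)C2`: 7430 nM
Compound 3 `NC(=O)c1c(NC(=O)c2ccccc2Br)sc2c1CCN(C(=S)Nc1ccccc1Cl)C2`: 12900 nM

In a functional assay on MKN-74 cells (Homo sapiens) for antiproliferative activity, with a stated time of 24 h (a lower number here means a stronger inhibitor, a higher number a weaker inhibitor), compound 1 reaches only a limit of the assay, so its result is not a number. Of the two compounds that give a number, compound 3 has the higher one, but compound 2 lies within the usual scatter of it, so the two cannot be told apart on these data. Compound 4 `NC(=O)c1c(NC(=O)c2ccc(C(F)(F)F)cc2)sc2c1CCN(C(=S)Nc1ccccc1Cl)C2` has not yet been measured. It differs from compound 3 in one place: 4-(trifluoromethyl)phenyl in place of 2-bromophenyl on a carbonyl carbon. Among the compounds with values here, no measured pair of compounds shows this change by itself, so its size has to be judged indirectly. What is known is that compound 1 also carries the 4-(trifluoromethyl)phenyl on its carbonyl carbon and gives > 50000 nM. The step expected from that change is a 1.9-fold higher number from compound 3 to compound 4 (0.29 log units; within the scatter), toward weaker inhibition and somewhat beyond the scatter. Compound 4 is therefore estimated at 25000 nM, with a likely range from 8000 nM to 80000 nM, and a real chance that the assay reports only a limit.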

Compound 4, half-maximal inhibitory concentration: 16400 nM
Compound 4: the middle estimate sits 1.5-fold (0.18 log units) above what was measured, within the range that was stated.
By their numbers in this assay, from the lowest: compounds 2, 3 and 4 (each within the scatter of the next, the first and the last beyond it). At a limit, above all of these: compound 1.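

On the carbonyl carbon, 4-(trifluoromethyl)phenyl in place of 2-bromophenyl gives a 1.3-fold higher number from compound 3 to compound 4 (0.10 log units; within the scatter) in this assay, so with the rest of the molecule held the same, this swap cannot be told apart from no change. With 4-(trifluoromethyl)phenyl held fixed instead, changing the group on the amine nitrogen in the ring gives an at least 3.0-fold lower number from compound 1 to compound 4 (0.48 log units; beyond the scatter), so this position, unlike the carbonyl carbon, shows a change beyond the scatter. Compound 1 gives only a limit and not a number, so the full size of that step cannot be read: the limit of > 50000 nM in this assay, at which 1 of the 4 values shown sits.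

Which part of the group on the ring nitrogen accounts for the step remains open. So does whether an amine or a carboxylic acid on the phenyl ring at the carbonyl carbon would move the number.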